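Moving the hydroxy group on a urea's phenyl ring

The source may hold more compounds than are shown below. What is called first, only, known or untested is meant among the compounds shown, and "the series" means these compounds.

Values in a functional assay on SW-620 cells (Homo sapiens) for inhibition, read by MTT assay, with a stated time of 72 h; a lower number here means a stronger inhibitor, a higher number a weaker inhibitor:
Compound 1 `COc1cc(NC(C)CCCNC(=O)Nc2cccc(Cl)c2)c2ncccc2c1`: 26000 nM
Compound 2 `COc1cc(NC(C)CCCNC(=O)NNC(=O)Nc2ccc(F)cc2)c2ncccc2c1`: > 100000 nM, a limit of the assay
Compound 3 `COc1cc(NC(C)CCCNC(=O)Nc2cccc(O)c2)c2ncccc2c1`: 27000 nM

Going by the values given here, compound 3 stands level with compound 1, the only other true number here. Compound 4 `COc1cc(NC(C)CCCNC(=O)Nc2ccc(O)cc2)c2ncccc2c1` carries 4-hydroxyphenyl in place of 3-hydroxyphenyl on an amide-type nitrogen. Among the compounds with values here, no measured step makes this exact change. The closest, hydroxy in place of chloro, gave a 1.0-fold higher number from compound 1 to compound 3 (0.02 log units; within the scatter). The larger at least 3.8-fold higher number from compound 1 to compound 2 (0.58 log units; beyond the scatter) replaced the whole 3-chlorophenyl group, a far bigger change, so it says less here. No shift beyond the scatter is therefore expected, and the estimated step is no change at the digits printed from compound 3 to compound 4 (within the scatter). For compound 4, the expected value is 27000 nM, with an estimated range of 12000 nM to 60000 nM.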

Compound 4, half-maximal inhibitory concentration: 30000 nM
For compound 4 the middle estimate is 1.1-fold (0.05 log units) below the measured one; the range from low to high includes it.
By their numbers in this assay, from the lowest: compounds 1, 3 and 4 (each within the scatter of the next). At a limit, above all of these: compound 2.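

Moving the hydroxy group, with 4-hydroxyphenyl in place of 3-hydroxyphenyl on the amide-type nitrogen, leaves the result unchanged within the scatter (a 1.1-fold higher number from compound 3 to compound 4 (0.05 log units; within the scatter)). Compound 4 also stands level with the chloro-bearing compound (a 1.2-fold higher number from compound 1 to compound 4 (0.06 log units; within the scatter)), so neither hydroxy placement separates from chloro. The one clear gap (an at least 3.3-fold lower number from compound 2 to compound 4 (0.52 log units; beyond the scatter)) starts from a limit, not a true number: the limit of > 100000 nM in this assay, at which 1 of the 4 values shown sits.

From the compounds shown here alone, what remains open is whether an amine or a carboxylic acid on this phenyl ring, or a longer chain on the shared core, would move the number beyond the scatter.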